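The source may hold more compounds than are shown below. What is called first, only, known or untested is meant among the compounds shown, and "the series" means these compounds.

Compound 1 `N#Cc1ccccc1/C=N/Nc1nc(N)c2ncn([C@@H]3O[C@H](CO)[C@@H](O)[C@H]3O)c2n1` carries a 2-cyanophenyl group on the carbon with a double bond to nitrogen, and in an assay on CHO-K1 cells for displacement of a labelled ligand from adenosine receptor A1 (Homo sapiens), read by scintillation counting, with a stated time of 60 min (a lower number here means a stronger inhibitor, a higher number a weaker inhibitor), compound 1 gives 2.9 nM. Compound 2 `Nc1nc(N/N=C/c2ccc(Cl)c(C(F)(F)F)c2)nc2c1ncn2[C@@H]1O[C@H](CO)[C@@H](O)[C@H]1O` carries a 4-chloro-3-(trifluoromethyl)phenyl group in that place. In this assay compound 2 gives only a limit of the assay, > 10000 nM. Compound 3 `CN(C)c1ccc(/C=N/Nc2nc(N)c3ncn([C@@H]4O[C@H](CO)[C@@H](O)[C@H]4O)c3n2)cc1` carries a 4-(dimethylamino)phenyl group in the same place. In this assay compound 3 likewise gives only a limit, > 10000 nM, and so stands at the limit of > 10000 nM in this assay, at which 2 of the 3 values shown sit. From compound 1 the change is an at least 3400-fold higher number from compound 1 to compound 2 (3.53 log units; beyond the scatter) and an at least 3400-fold higher number from compound 1 to compound 3 (3.53 log units; beyond the scatter), while between the two limits there is a step that the two limits leave unreadable from compound 2 to compound 3.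

Compound 4 `N#Cc1ccc(/C=N/Nc2nc(N)c3ncn([C@@H]4O[C@H](CO)[C@@H](O)[C@H]4O)c3n2)cc1` differs from compound 3 by cyano in place of dimethylamino on an aromatic carbon. The measured step that bears on this is an at least 3400-fold higher number from compound 1 to compound 3 (3.53 log units; beyond the scatter), which shows the 2-cyanophenyl compound far ahead of the dimethylamino compound. Compound 4 brings a cyano group back, but as 4-cyanophenyl rather than the 2-cyanophenyl of compound 1, so only part of that gain is expected to return: the step of an at least 3.3-fold lower number from compound 3 to compound 4 (0.52 log units; beyond the scatter) is expected to move toward a stronger inhibitor, with compound 4 estimated at 3000 nM, within a range of 300 nM to 20000 nM.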

Compound 4, inhibition constant: 4.1 nM
For compound 4 the middle estimate is 730-fold (2.86 log units) above the measured one; the measured number lies below the stated range.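

The swap from 2-cyanophenyl to 4-cyanophenyl leaves no readable difference in this assay, with a 1.4-fold higher number from compound 1 to compound 4 (0.15 log units; within the scatter), so compound 1 and compound 4 cannot be ordered and the cyano group is tolerated at either place on the phenyl ring. Set para to the large group, the cyano group therefore restores the full level: cyano in place of dimethylamino gives an at least 2400-fold lower number from compound 3 to compound 4 (3.38 log units; beyond the scatter), and 4-cyanophenyl in place of 4-chloro-3-(trifluoromethyl)phenyl gives an at least 2400-fold lower number from compound 2 to compound 4 (3.38 log units; beyond the scatter). Both of these steps start from a limit of the assay, not a number, so their true size stays unknown: the limit of > 10000 nM in this assay, at which 2 of the 4 values shown sit.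

The compounds shown leave open whether a plain phenyl ring, or a carboxylic acid or primary amide in place of the cyano group, would hold this level. They also cannot show whether the chloro or the trifluoromethyl group of compound 2 goes with its weak result.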